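A few compounds are considered here, and "the series" means these few. Any claim that something is new, unique, unknown or untested is made for them only; others in the source may bear on it.

Measured compounds in a functional assay on SN12C cells (Homo sapiens) for inhibition, read by sulforhodamine B assay, with a stated time of 48 h; a higher number here means a weaker inhibitor of growth, a lower number a stronger inhibitor of growth:
compound 1, `COc1ccc(-c2ccc(-c3ccc(C(=N)N)o3)o2)cc1`: 2020 nM
compound 2, `N=C(N)c1ccc(-c2ccc(-c3cncc4ccccc34)s2)s1`: 1800 nM
compound 3, `COc1cc(OC)cc(-c2ccc(-c3ccc(C(=N)N)o3)o2)c1`: 2380 nM

Compound 1 stands second highest of the three numbers; its nearest neighbour is compound 2, its furthest compound 3, and both gaps lie within the usual scatter, so the three values give no ordering. For the measured compounds named here, no pair of measured compounds differs in just one place, so no single step is known from the numbers in hand. Compound 4, `N=C(N)c1ccc(-c2ccc(-c3ccc(F)cc3)o2)o1`, is not yet measured in this assay. From compound 1 it differs by fluoro in place of methoxy on an aromatic carbon: methoxy leaves and fluoro enters, on an aromatic carbon of a six-membered aromatic ring of carbon only. Going by the values given here, with no comparable step among the measured compounds, the expected step of a 1.1-fold higher number from compound 1 to compound 4 (0.04 log units; within the scatter) is small, with no direction beyond the scatter. Compound 4 is expected at 2200 nM, in the range 1000 nM to 5000 nM.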

Compound 4, concentration for 50% growth inhibition: 1800 nM
Compound 4: the middle estimate sits 1.2-fold (0.09 log units) above what was measured; measured number inside the range.
By their numbers in this assay, from the lowest: compounds 2, 4, 1 and 3 (each within the scatter of the next).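

In this assay fluoro in place of methoxy on an aromatic carbon, para to a large group, gives the series its first single-place step (a 1.1-fold lower number from compound 1 to compound 4 (0.05 log units; within the scatter)). At this position the two groups are therefore not separated by the numbers, although the smaller fluoro replaces the methoxy oxygen and its methyl carbon. No measured evidence bears on why the two read alike.

As far as these compounds go, whether an amine, a carboxylic acid or a longer chain such as butoxy at this position would give a step beyond the scatter remains open. So does whether any replacement here can separate compounds at all.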